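From 1H-indol-6-yl to 4-acetylphenyl on the shared core

A few compounds are considered here, and "the series" means these few. Any claim that something is new, unique, unknown or untested is made for them only; others in the source may bear on it.

Compound 1 `COc1cc(-c2ccnc3cc(-c4ccc(C)cc4)nn23)cc(OC)c1OC` gives 3 nM in the first measurement
Compound 2 `COc1cc(-c2ccnc3cc(-c4ccc(C)c(C)c4)nn23)cc(OC)c1OC` gives 272 nM in the second
Compound 3 `COc1cc(-c2ccnc3cc(-c4ccc5cc[nH]c5c4)nn23)cc(OC)c1OC` gives 170 nM in the third

In a functional assay on A549 cells (Homo sapiens) for inhibition, read by CCK-8 assay, with a stated time of 48 h (a higher number here means a weaker inhibitor, a lower number a stronger inhibitor), compound 3 (170 nM) is not separated from compound 2 (272 nM) and sits well above compound 1 (3 nM) on the scale. Compound 4 `COc1cc(-c2ccnc3cc(-c4ccc(C(C)=O)cc4)nn23)cc(OC)c1OC` brings 4-acetylphenyl in place of 1H-indol-6-yl on an aromatic carbon in that same place. Going by the values given here, two measured steps bear on this: a 57-fold higher number from compound 1 to compound 3 (1.75 log units; beyond the scatter) for the exchange of one group for another there, and a 91-fold higher number from compound 1 to compound 2 (1.96 log units; beyond the scatter) for a single added methyl. Both were large, so this group can move the number strongly, yet neither shows how acetyl will act. The estimated step is a 1.7-fold lower number from compound 3 to compound 4 (0.23 log units; within the scatter) with no firm shift beyond the scatter expected. For compound 4 the expected value is 100 nM (estimated range 12 nM to 800 nM).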

Compound 4, half-maximal inhibitory concentration: 4100 nM
For compound 4 the middle estimate is 41-fold (1.61 log units) below the measured one; the measured number lies above the stated range.
By their numbers in this assay, from the lowest: compound 1; then compounds 3 and 2 (each within the scatter of the next); then compound 4.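

At this aromatic carbon of the shared core, 4-acetylphenyl stands clearly apart from every other group shown in this assay (a 24-fold higher number from compound 3 to compound 4 (1.38 log units; beyond the scatter); a 15-fold higher number from compound 2 to compound 4 (1.18 log units; beyond the scatter)). Acetyl in place of methyl alone gives the widest gap among these compounds (a 1400-fold higher number from compound 1 to compound 4 (3.14 log units; beyond the scatter)), so the earlier steps had not reached the full range of this position. No available evidence explains this change. From the compounds shown here alone, it remains open whether an amine, a hydroxyl group or a carboxylic acid in place of the acetyl would give a number nearer that of compound 1 or that of compound 4.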